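Bromo to trifluoromethyl at the pendant aryl ring

The source may hold more compounds than are shown below. What is called first, only, known or untested is meant among the compounds shown, and "the series" means these compounds.

Measured compounds in a functional assay on MCF7 cells (Homo sapiens) for inhibition, read by sulforhodamine B assay, with a stated time of 72 h; on this read-out lower numbers stand for stronger inhibition and higher numbers for weaker inhibition:
compound 1 `CC(C)Cc1ccc(C(C)c2nnc3n2N=C(c2ccc(OC(F)(F)F)cc2)CS3)cc1` gives 1100 nM
compound 2 `COc1ccc(C2=Nn3c(nnc3C(C)c3ccc4cc(OC)ccc4c3)SC2)cc1` gives 6600 nM
compound 3 `CC(C)Cc1ccc(C(C)c2nnc3n2N=C(c2ccc(Br)cc2)CS3)cc1` gives 9400 nM

Compound 3 stands at the highest of the three numbers in this assay. Its nearest neighbour is compound 2, whose value lies within the scatter of compound 3, so no order between those two can be claimed; compound 1 sits well apart, and the step of an 8.5-fold higher number from compound 1 to compound 3 (0.93 log units; beyond the scatter) is beyond the scatter.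

Compound 4 `CC(C)Cc1ccc(C(C)c2nnc3n2N=C(c2ccc(C(F)(F)F)cc2)CS3)cc1` has not yet been measured. It differs from compound 3 in one place: trifluoromethyl in place of bromo on an aromatic carbon. Among the measured compounds shown here, the single measured step that bears on this change is an 8.5-fold higher number from compound 1 to compound 3 (0.93 log units; beyond the scatter), in which bromo entered for a fluorinated group and the number rose. Going the other way, from bromo to trifluoromethyl, that step suggests a fall in the number, though trifluoromethyl is not trifluoromethoxy, so the size is uncertain.

For compound 4 the value expected in this assay is 3500 nM, with a range from 1000 nM to 12000 nM; this estimate means the step of a 2.7-fold lower number from compound 3 to compound 4 (0.43 log units; beyond the scatter).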

Compound 4, half-maximal inhibitory concentration: 4200 nM
Beside the measured number, compound 4's estimate is 1.2-fold (0.08 log units) below it; the range from low to high includes it.
By their numbers in this assay, from the lowest: compound 1; then compounds 4, 2 and 3 (each within the scatter of the next, the first and the last beyond it).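

In this assay the step of a 2.2-fold lower number from compound 3 to compound 4 (0.35 log units; beyond the scatter) shows that this place on the aromatic ring still responds when bromo gives way to a group other than trifluoromethoxy, so the earlier difference was not specific to that one pair. The step of a 3.8-fold higher number from compound 1 to compound 4 (0.58 log units; beyond the scatter) adds that trifluoromethyl does not match trifluoromethoxy here, which means that a fluorinated group alone does not secure the number of compound 1, and the three groups now fall in a clear order: trifluoromethoxy, then trifluoromethyl, then bromo, from lowest number to highest. Nothing available accounts for this order. The compounds shown leave open how a nitrile, a methyl group or an amine would rank at this place. They also leave open whether the order would survive a change elsewhere in the molecule.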